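Adding a Second Chloro to a Purine Core

This account rests on a few compounds, and the source may have more. Where it says the series, first, only, none or still open, it means among the compounds named here.

Compound 1 `ClCc1ccccc1Cn1cnc2c(Cl)nc(Cl)nc21`: 3310 nM
Compound 2 `ClCc1cccc(Cn2cnc3c(Cl)ncnc32)c1`: 33900 nM

Both numbers come from a functional assay on IGROV-1 cells (Homo sapiens) for cytotoxicity, read by sulforhodamine B assay, with a stated time of 48 h; on this read-out lower numbers stand for stronger inhibition of growth and higher numbers for weaker inhibition of growth. Compound 2 holds the highest of the two numbers; compound 1 sits lower by a gap beyond the usual scatter, yet the two compounds differ in two places, so no single change explains that gap. Compound 3 `ClCc1cccc(Cn2cnc3c(Cl)nc(Cl)nc32)c1` differs from compound 2 by one change only: chloro in place of hydrogen on an aromatic carbon. For the measured compounds named here, no measured pair isolates this change. In this assay the step from compound 2 to compound 3 is expected to be downward and beyond the scatter, a 5.7-fold lower number from compound 2 to compound 3 (0.75 log units; beyond the scatter). For compound 3 the expected value is 6000 nM, within 1500 nM to 25000 nM.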

Compound 3, concentration for total growth inhibition: 5120 nM
For compound 3 the middle estimate is 1.2-fold (0.07 log units) above the measured one; the measured number falls inside the stated range.
By their numbers in this assay, from the lowest: compounds 1 and 3 (each within the scatter of the next); then compound 2.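

On the aromatic carbon between two ring nitrogen atoms, chloro in place of hydrogen gives, in this assay, a 6.6-fold lower number from compound 2 to compound 3 (0.82 log units; beyond the scatter) with nothing else altered. This pair isolates that single change, which compound 1 and compound 2, differing in two places, could not do. Nothing available explains why this change shifts the number. The compounds shown leave open what an amine or a methoxy group on that same carbon would do. They also leave open whether a fluoro or bromo group there would give a similar step.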